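Fluoro to hydrogen on the aryl ring: compound 2 to compound 3

A few compounds are considered here, and "the series" means these few. Any claim that something is new, unique, unknown or untested is made for them only; others in the source may bear on it.

Of the compounds shown here, two sharing one core have been measured so far. Compound 1 `Fc1ccc2c(=S)cc(-c3ccccc3)oc2c1` and compound 2 `COc1ccc2c(=S)cc(-c3ccc(F)cc3)oc2c1` were both tested in an in vitro assay on BTI-TN-5B1-4 cells for inhibition of Amine oxidase [flavin-containing] B (Homo sapiens), tested at 100 uM; a lower number here means less inhibition, a higher number more inhibition at the concentration tested (going by the name of the read-out). In this assay compound 1 gives 40%. In this assay compound 2 gives 40%. Compound 2 therefore stands level with compound 1 at the digits shown, and its nearest neighbour in this set is compound 1, with no change beyond the scatter. The two compounds differ in more than one place, so no single structural step can be read from that pair.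

Compound 3 `COc1ccc2c(=S)cc(-c3ccccc3)oc2c1` has not yet been measured. It differs from compound 2 in one place: hydrogen in place of fluoro on an aromatic carbon. Among the measured compounds shown here, no measured pair in this set isolates this change, so what follows is an expectation rather than a measured step. Because compound 1, which carries an unsubstituted phenyl ring, gives 40%, and compound 2 gives 40%, the account expects the step of no change at the digits printed from compound 2 to compound 3 (within the scatter) to be none beyond the scatter. Compound 3 is accordingly estimated to give 40% in this assay, with a range from 25% to 55%.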

Compound 3, a percentage reported as inhibition, at one concentration (the size of the read-out at that concentration, not a potency): 40%
Beside the measured number, compound 3's estimate shows no gap at the digits printed; measured number inside the range.
By their numbers in this assay, from the lowest: compounds 1, 2 and 3 (each within the scatter of the next).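

In this assay, putting hydrogen in place of fluoro on an aromatic carbon of the six-membered aromatic ring of carbon only, para to a large group, gives no change at the digits printed from compound 2 to compound 3 (within the scatter), so this change now stands as a measured step rather than an expectation. The second single-place comparison, methoxy in place of fluoro on an aromatic carbon, gives no change at the digits printed from compound 1 to compound 3 (within the scatter), so neither of these two swaps moves the read-out beyond the scatter at the one concentration tested. Nothing available here offers an explanation for this lack of separation.

The compounds shown leave open whether any group at these places would separate from fluoro, hydrogen and methoxy, for example an amine or a carboxylic acid on the same aromatic carbon, or a longer chain in place of methoxy. They also leave open whether compounds that read alike at this single concentration would still read alike in a measure of potency, which a percentage at one concentration does not give.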